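Nitro for chloro on the fused ring of compound 1

The compounds below may be only part of what the source reports. "The series", "measured", "known", "first", "only" and "open" are said of these compounds alone.

Compound 1 `CC(=O)N1N=C(Nc2nc3ccc(Cl)cc3s2)CC1OC1=CC=C1` carries a chloro group on the fused aromatic ring and a four-membered ring on the saturated ring carbon. In a functional assay on the whole organism (Hindlimb, strain albino) with Mus musculus as the target, in the maximal electroshock model, with a stated time of 0.5 h (a higher number here means that more compound is needed for the effect, a lower number that less compound is needed), compound 1 gives 212 umol/kg, the highest of the three numbers, though both neighbours sit within the scatter of it. Compound 2 `CC(=O)N1N=C(Nc2nc3ccc(Cl)cc3s2)CC1c1ccc(O)cc1` gives 106 umol/kg and compound 3 `COc1ccc(C2CC(Nc3nc4ccc(Cl)cc4s3)=NN2C(C)=O)cc1O` gives 127 umol/kg. The three steps among them, a 2.0-fold lower number from compound 1 to compound 2 (0.30 log units; within the scatter), a 1.7-fold lower number from compound 1 to compound 3 (0.22 log units; within the scatter) and a 1.2-fold higher number from compound 2 to compound 3 (0.08 log units; within the scatter), all change only the group on the saturated ring carbon, and none of them leaves the scatter.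

Compound 4 `CC(=O)N1N=C(Nc2nc3ccc([N+](=O)[O-])cc3s2)CC1OC1=CC=C1` differs from compound 1 in a different place, on the fused ring: nitro in place of chloro on an aromatic carbon. Among the compounds with values here, no measured step touches the chloro position, so nothing among the measured compounds bears directly on this change. With the replaced group being a single-atom halogen and the entering nitro group small as well, compound 4 is expected to stay close to compound 1, with the step of a 1.0-fold lower number from compound 1 to compound 4 (0.00 log units; within the scatter) expected not to exceed the scatter. Compound 4 is therefore estimated at 210 umol/kg, with a range from 95 umol/kg to 460 umol/kg.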

Compound 4, dose for half-maximal effect: 274 umol/kg
Compound 4: middle estimate off by 1.3-fold (0.12 log units), on the low side; measured number inside the range.
By their numbers in this assay, from the lowest: compounds 2, 3, 1 and 4 (each within the scatter of the next, the first and the last beyond it).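

Within the data shown here, the step of a 1.3-fold higher number from compound 1 to compound 4 (0.11 log units; within the scatter) in this assay is the first measured change on the fused ring, and it shows that this read-out does not separate nitro from chloro on this aromatic carbon. This holds for one background only, with the four-membered ring of compound 1 on the saturated ring carbon, the only background on which both groups are shown. Nothing available bears on why the two groups read alike.

As far as these compounds go, whether the same exchange stays within the scatter with 4-hydroxyphenyl or 3-hydroxy-4-methoxyphenyl on the saturated ring carbon remains open. Also open, from the compounds shown here alone, is how this position responds to an entirely different group, such as an amine, a carboxylic acid or a longer alkyl chain, or to plain hydrogen.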